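The compounds below may be only part of what the source reports. "The series", "measured", "known", "first", "only" and "open" are said of these compounds alone.

Measured compounds: compound 1, `O=C1c2c[n+]([O-])c3ccccc3c2C(=O)c2[nH]c3ccccc3c21`, gives 890 nM; compound 2, `O=C1c2c[n+]([O-])c3ccccc3c2C(=O)c2c1c1ccccc1n2CCCCN1CCNCC1`, gives 760 nM.

Both values come from a toxicity assay on HEK-293T cells (Homo sapiens) for cytotoxicity, read by MTT assay, with a stated time of 72 h; a higher number here means a weaker inhibitor, a lower number a stronger inhibitor. Compound 2 stands at the lower of the two numbers, but the gap to compound 1 is small: a 1.2-fold lower number from compound 1 to compound 2 (0.07 log units; within the scatter), a change that lies within the usual scatter, so the two compounds are best read as equal.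

Compound 3, `CN(C)CCCCn1c2c(c3ccccc31)C(=O)c1c[n+]([O-])c3ccccc3c1C2=O`, is the next compound. Compared with compound 2 it shows (dimethylamino in place of piperazin-1-yl on a saturated chain carbon, four bonds along the chain from an aromatic nitrogen).

Among the compounds with values here, no measured step involves this exact exchange. Within the data shown here, the only step available, from compound 1 to compound 2, concerns the presence of the whole chain rather than the group at its end, and that step was within the scatter. With nothing more to go on, no step beyond the scatter is expected in this assay.

The estimate for compound 3 is therefore 800 nM, with a range of 300 nM to 2500 nM, which means an expected step of a 1.1-fold higher number from compound 2 to compound 3 (0.02 log units; within the scatter).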

Compound 3, half-maximal inhibitory concentration: 520 nM
Compound 3: middle estimate off by 1.5-fold (0.19 log units), on the high side; low and high end bracket the measured number.
By their numbers in this assay, from the lowest: compounds 3, 2 and 1 (each within the scatter of the next).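

In this assay, dimethylamino in place of piperazin-1-yl at the end of the chain gives a 1.5-fold lower number from compound 2 to compound 3 (0.16 log units; within the scatter), so on this saturated chain carbon, four bonds along the chain from an aromatic nitrogen, an amine with no ring and no hydrogen-bond donor reads the same as the larger ring amine. Setting 4-(dimethylamino)butyl in place of hydrogen on the aromatic nitrogen gives a 1.7-fold lower number from compound 1 to compound 3 (0.23 log units; within the scatter), so neither chain-bearing compound can yet be told apart from compound 1. No measurement at hand accounts for how closely these numbers sit.

Still open, as far as these compounds go, is whether a carboxylic acid or a morpholine ring at the chain end would give a step beyond the scatter. From the compounds shown here alone, a shorter or longer chain carrying the same dimethylamino group is equally open.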